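Nitro in place of ethoxycarbonyl on compound 2

The source may report more compounds than this note shows. Statements on the series, on what has been measured and on what is new or still open speak of the compounds shown alone.

In a functional assay on HCT-116 cells (Homo sapiens) for antiproliferative activity, read by MTT assay, with a stated time of 72 h (a higher number here means a weaker inhibitor, a lower number a stronger inhibitor), compound 1 `O=C(CCc1cccc2c1B(O)OC2)Nc1ccccc1` gives 350 nM. Compound 2 `CCOC(=O)c1ccc(NC(=O)CCc2cccc3c2B(O)OC3)cc1` gives > 100000 nM, which is a limit and not a number. Compound 3 `O=C(CCc1cccc2c1B(O)OC2)Nc1ccc([N+](=O)[O-])cc1` carries nitro in place of ethoxycarbonyl on an aromatic carbon. Among the measured compounds shown here, the one measured step that bears on this is an at least 280-fold higher number from compound 1 to compound 2 (2.45 log units; beyond the scatter), which introduced ethoxycarbonyl in place of hydrogen, so a partial return toward compound 1 is expected, a large step to a lower number in this assay. The expected change is an at least 12-fold lower number from compound 2 to compound 3 (1.09 log units; beyond the scatter). For compound 3 the estimated value is 8000 nM, with an expected range of 800 nM to 80000 nM.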

Compound 3, half-maximal inhibitory concentration: > 100000 nM
Compound 3 gave a limit, no number; the forecaster's own chance of this, stated with the estimate: 25%; middle value at least 12-fold (1.09 log units) from the limit.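

In this assay, the loss seen with ethoxycarbonyl is not particular to that group: nitro on the same aromatic carbon, para to a large group, also gives an at least 280-fold higher number from compound 1 to compound 3 (2.45 log units; beyond the scatter). The step from compound 2 to compound 3 cannot be read, and the two groups cannot be ranked, because both compounds sit at one limit: the limit of > 100000 nM in this assay, at which 2 of the 3 values shown sit.

As far as these compounds go, what stays open is whether an amine, a methoxy group or fluorine on this carbon would keep the activity of compound 1. Also open, from the compounds shown here alone, is whether either group would cost as much on another carbon of this ring.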